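This account rests on a few compounds, and the source may have more. Where it says the series, first, only, none or still open, it means among the compounds named here.

Compound 1 `Cc1nnc(SCC(=O)Nc2ccc(-c3nc(-c4ccccc4)c(-c4ccccc4)n3C)cc2)s1` and compound 2 `CN1CCN(CC(=O)Nc2ccc(-c3nc(-c4ccccc4)c(-c4ccccc4)n3C)cc2)CC1` share one core. In a functional assay on MCF7 cells (Homo sapiens) for cytotoxicity, read by MTT assay, with a stated time of 24 h, tested at 0.64 ug/mL (a higher number here means a stronger effect of the compound at the concentration tested, a lower number a weaker effect), compound 1 gives 35.1%, while compound 2 gives 1.1%, the lower of the two, after a step of a number 34 percentage points lower from compound 1 to compound 2 (beyond the scatter). Compound 3 `COc1ccc(CN2CCN(CC(=O)Nc3ccc(-c4nc(-c5ccccc5)c(-c5ccccc5)n4C)cc3)CC2)cc1` arises from compound 2 by a single change, (4-methoxyphenyl in place of hydrogen on a saturated chain carbon bound to an amine nitrogen in a ring). For the measured compounds named here, no measured step touches this position; the only step seen concerns the group on the saturated chain carbon bound to a carbonyl carbon, so it offers no direct guide. With compound 2 so low, a shift of a number 8.9 percentage points higher from compound 2 to compound 3 (within the scatter) is expected for compound 3, giving an estimated 10% within 0% to 30%.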

Compound 3, a percentage reported as activity, at one concentration (the size of the read-out at that concentration, not a potency): 1%
The estimate for compound 3 lay 9 percentage points above the measured number; measured number inside the range.
By their numbers in this assay, from the lowest: compounds 3 and 2 (each within the scatter of the next); then compound 1.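

Placing 4-methoxyphenyl on the saturated chain carbon bound to an amine nitrogen in a ring, which turns methyl into 4-methoxybenzyl, gives a number 0.1 percentage points lower from compound 2 to compound 3 (within the scatter) in this assay for this pair. This first reading at this position shows no difference beyond the scatter, even with the added aromatic ring. Yet compound 2 already gives 1.1% here, so any loss from this change could hardly be seen. Going by these compounds, whether an amine or a carboxylic acid on this carbon would read differently stays open. No available evidence bears on this result.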